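This account rests on a few compounds, and the source may have more. Where it says the series, first, only, none or still open, it means among the compounds named here.

The series shares one core, shown in `O=C1Nc2cc(Br)ccc2/C1=C\c1cccc(OCc2cn(Cc3ccccc3)nn2)c1` for compound 1, which carries bromo on the fused system; in a functional assay on MDA-MB-231 cells (Homo sapiens) for inhibition, read by MTT assay, with a stated time of 48 h (a lower number here means a stronger inhibitor, a higher number a weaker inhibitor), compound 1 gives "not determined" (no result reported). Compound 2, `O=C1Nc2ccc(F)cc2/C1=C\c1cccc(OCc2cn(Cc3ccccc3)nn2)c1`, carries fluoro in its place. In this assay compound 2 gives > 50000 nM, which is a limit of the assay and not a number. Among the compounds with values here, compound 2 thus stands at the limit of > 50000 nM in this assay, at which 1 of the 2 values shown sits, and the only other entry carries no number, so no measured step is available to set a scale.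

Compound 3, `O=C1Nc2ccc(C(=O)c3ccccc3)cc2/C1=C\c1cccc(OCc2cn(Cc3ccccc3)nn2)c1`, is the next member to be run. It differs from compound 2 by benzoyl in place of fluoro on an aromatic carbon. The exchange sits on the aromatic carbon of the fused system that in compound 2 bears fluoro.

With compound 2 resting at a limit, the measured data give no direction for this change. The step from compound 2 to compound 3 in this assay is expected to be an at least 1.2-fold lower number from compound 2 to compound 3 (0.09 log units; that floor lies within the scatter). For compound 3 the estimate in this assay is 40000 nM, with a range from 8000 nM to 200000 nM, and a fair chance that only a limit is again reported.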

Compound 3, half-maximal inhibitory concentration: > 50000 nM
Compound 3 was reported as a limit; the forecaster's own chance of this, stated with the estimate: 55%; middle value at least 1.2-fold (0.09 log units) away from the limit.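

In this assay compound 3 gives > 50000 nM, which is a limit of the assay and not a number. No step from compound 2 to compound 3 can be read, since both rest at a limit: the limit of > 50000 nM in this assay, at which 2 of the 3 values shown sit.

The compounds shown leave open what change, in size or direction, benzoyl in place of fluoro brings in this assay.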